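The source may hold more compounds than are shown below. What is called first, only, known or untested is meant among the compounds shown, and "the series" means these compounds.

Going by the values given here, compound 2 `COc1cc(NC(=O)Nc2cc(Nc3cc(Br)ccc3OC)ncn2)cc(OC)c1` gives the higher of the two numbers measured so far: in a functional assay on HCC827 cells (Homo sapiens) for inhibition, read by MTT assay, with a stated time of 48 h, tested at 10 uM (a lower number here means less inhibition, a higher number more inhibition at the concentration tested (going by the name of the read-out)), compound 2 gives 76.3%. Its nearest neighbour, compound 1 `COc1cc(NC(=O)Nc2cc(Nc3cc(F)ccc3OC)ncn2)cc(OC)c1`, gives 59% in this assay, and the step with bromo in place of fluoro on an aromatic carbon reads a number 17.3 percentage points higher from compound 1 to compound 2 (beyond the scatter).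

Compound 3 `COc1cc(NC(=O)Nc2cc(Nc3cc(C)cc(F)c3)ncn2)cc(OC)c1` differs from compound 2 by 3-fluoro-5-methylphenyl in place of 5-bromo-2-methoxyphenyl on a nitrogen on an aromatic ring. Among the compounds with values here, the one measured step bears on this only in part: it shows that a fluoro-bearing ring gave a modestly lower number than a bromo-bearing ring, while no measured pair tells what removing the methoxy and adding the methyl does. On that basis a modest fall in this assay is expected, with a number 18.3 percentage points lower from compound 2 to compound 3 (beyond the scatter) as the estimated step from compound 2 to compound 3. Compound 3 is therefore estimated at 58% in this assay, with a likely range from 40% to 76%.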

Compound 3, a percentage reported as inhibition, at one concentration (the size of the read-out at that concentration, not a potency): 62.1%
The estimate for compound 3 lay 4.1 percentage points below the measured number; low and high end bracket the measured number.
By their numbers in this assay, from the lowest: compounds 1 and 3 (each within the scatter of the next); then compound 2.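

In this assay, the change at this position, on a nitrogen on an aromatic ring, reads a number 14.2 percentage points lower from compound 2 to compound 3 (beyond the scatter), so the 3-fluoro-5-methylphenyl ring does not match the 5-bromo-2-methoxyphenyl ring. Set against the 5-fluoro-2-methoxyphenyl ring, the same entering group reads a number 3.1 percentage points higher from compound 1 to compound 3 (within the scatter), so among these three compounds only the bromo-bearing ring stands apart, while two rings with different groups around the fluoro cannot be told apart. No measurement shown gives a cause for this.

The compounds shown leave open how much of the number of compound 2 goes with the bromo and how much with the methoxy, as no pair here changes the methoxy alone. They also leave open how a chloro or a trifluoromethyl on this ring would read.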